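Lengthening the amide side chain at the assay limit

The source may report more compounds than this note shows. Statements on the series, on what has been measured and on what is new or still open speak of the compounds shown alone.

Compound 1 `O=C(NCC1CCNCC1)c1c[nH]c2cc(-c3ccc(-c4ccccc4)cc3)ccc12` gives > 10000 nM as a limit
Compound 2 `O=C(NCC1CCNCC1)c1c[nH]c2cc(-c3ccc(CN4CCCCC4)cc3)ccc12` gives > 10000 nM as a limit
Compound 3 `O=C(NC1CCNCC1)c1c[nH]c2cc(-c3ccncc3)ccc12` gives > 10000 nM as a limit

All three readings come from an ADME assay on U-87MG ATCC cells for inhibition, with U-87 MG (Homo sapiens) as the target, read by MTT assay (on this read-out lower numbers stand for higher toxicity in this test and higher numbers for lower toxicity in this test), and none of them is an exact number. Compound 3 stands at > 10000 nM as a limit of the assay, so it has no exact place on the scale. Taken together, the record shows the limit of > 10000 nM in this assay, at which 3 of the 3 values shown sit, and no finer ranking can be read from it.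

Compound 4 `O=C(NCCC1CCNCC1)c1c[nH]c2cc(-c3ccncc3)ccc12` keeps the core of compound 3 and changes one group. The change is 2-(piperidin-4-yl)ethyl in place of piperidin-4-yl on an amide-type nitrogen and it puts 2-(piperidin-4-yl)ethyl in place of piperidin-4-yl on an amide-type nitrogen.

For the measured compounds named here, the only measured step is a step that the two limits leave unreadable from compound 1 to compound 2 and it concerns an aromatic carbon, not this nitrogen. It offers no size to carry over. No step beyond the scatter is expected in this assay and no direction can be named. Compound 4 is expected to stay at the limit as well, given the limit of > 10000 nM in this assay, at which 3 of the 3 values shown sit, across the measured compounds. The estimated step is a step that the limit leaves unreadable from compound 3 to compound 4 and it is not expected to mean a real change. The estimate for compound 4 is 14000 nM with an expected range of 6000 nM to 30000 nM and a reading at the limit is the likeliest result.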

Compound 4, half-maximal cytotoxic concentration: > 10000 nM
Compound 4 ended at the assay's limit; the forecaster's own chance of this, stated with the estimate: 85%; the middle value lies beyond the limit too.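

No size or direction can be read for the change from compound 3 to compound 4 in this assay because both readings are limits and not exact numbers: the limit of > 10000 nM in this assay, at which 4 of the 4 values shown sit. The compounds shown leave open at what concentration, if any, each one would harm these cells, and whether the longer 2-(piperidin-4-yl)ethyl chain alters that.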